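Adding an amino group to compound 1

The source may hold more compounds than are shown below. What is called first, only, known or untested is meant among the compounds shown, and "the series" means these compounds.

Compound 1 `CCn1cc(-c2nc3ccccc3[nH]2)c(=O)c2cc(F)c(N3CCNCC3)nc21` is the starting point. In a functional assay on AGS cells (Homo sapiens) for cytotoxicity, read by sulforhodamine B assay, with a stated time of 48 h (on this read-out higher numbers stand for weaker inhibition and lower numbers for stronger inhibition), compound 1 gives 6600 nM. Two related compounds have also been measured in this assay: compound 2 `CCn1cc(-c2nc3ccc([N+](=O)[O-])cc3o2)c(=O)c2cc(F)c(N3CCNC(C)C3)c(F)c21` gives 3500 nM, and compound 3 `CCn1cc(-c2nc3ccc([N+](=O)[O-])cc3o2)c(=O)c2cc(F)c(N3CCNCC3)nc21` gives 4400 nM. Compound 1 stands within the usual scatter of both, so these values support no ranking. Among the measured compounds shown here, no two measured compounds differ in one place only, so the data show no isolated effect of a single change.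

Compound 4 `CCn1cc(-c2nc3ccc(N)cc3[nH]2)c(=O)c2cc(F)c(N3CCNCC3)nc21` is compound 1 with amino in place of hydrogen on an aromatic carbon. That carbon belongs to a six-membered aromatic ring of carbon only, part of a fused or bridged system of two rings. For the measured compounds named here, no measured compound shows what this amino group does, so the expectation rests only on the narrow band of the three measured values, in which compounds 1, 2 and 3 stay close despite their structural differences. No step beyond the scatter is expected in this assay, in either direction. The estimated step, a 1.5-fold lower number from compound 1 to compound 4 (0.17 log units; within the scatter), is expected to remain within the scatter. Compound 4 is estimated at 4500 nM, with an expected range from 1500 nM to 13000 nM.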

Compound 4, half-maximal inhibitory concentration: 9200 nM
Compound 4: the middle estimate sits 2.0-fold (0.31 log units) below what was measured; low and high end bracket the measured number.
By their numbers in this assay, from the lowest: compounds 2, 3, 1 and 4 (each within the scatter of the next, the first and the last beyond it).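

In this assay, among the compounds shown here, amino in place of hydrogen on an aromatic carbon gives a 1.4-fold higher number from compound 1 to compound 4 (0.14 log units; within the scatter) as the first single-place step, so this change can now be read on its own rather than inferred from compounds that differ in several places. At this place, on a six-membered aromatic ring of carbon only, part of a fused or bridged system of two rings, compound 1 and compound 4 cannot be told apart, and the amino group gives no sign of either gain or loss in this read-out. The data offer no measured property that would account for this result.

Still open, from the compounds shown here alone, is whether a different group at the same place, such as a methoxy group, an acetamide or a carboxylic acid, would produce a step beyond the scatter. Also open, going by these compounds, is whether the amino group would give a similarly small step on the cores of compound 2 and compound 3, which cannot be judged from a single pair.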